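The source may report more compounds than this note shows. Statements on the series, on what has been measured and on what is new or still open speak of the compounds shown alone.

Measured in an ADME assay on MCF-10A cells (Homo sapiens) for cytotoxicity, read by MTT assay, with a stated time of 72 h; on this read-out lower numbers stand for stronger inhibition and higher numbers for weaker inhibition:
compound 1 `Cc1ccc(-c2ccc(F)cc2)n1-c1ccc(-c2nc3ccccc3s2)cc1`, 40000 nM
compound 2 `COc1ccc(-c2ccc(C)n2-c2ccc(-c3nc4ccccc4s3)cc2)cc1`, 36300 nM
compound 3 `Cc1ccc(-c2ccc(F)cc2)n1-c1ccc(-c2nc3ccc(F)cc3s2)cc1`, 37800 nM

The three measured numbers lie within the scatter of one another, so no order among them is claimed. Compound 4 `COc1ccc(-c2ccc(C)n2-c2ccc(-c3nc4ccc(F)cc4s3)cc2)cc1` is not yet measured. It stands to compound 3 as compound 2 stands to compound 1, through (methoxy in place of fluoro on an aromatic carbon). The same change was made once before, as methoxy in place of fluoro on an aromatic carbon, and gave a 1.1-fold lower number from compound 1 to compound 2 (0.04 log units; within the scatter). The place of the change is the same word for word in both pairs, so this is the same change. The two cores differ by fluoro in place of hydrogen on an aromatic carbon, which gave a 1.1-fold lower number from compound 1 to compound 3 (0.02 log units; within the scatter).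

The earlier occurrence of this change stayed within the scatter, and the core difference also stayed within the scatter, so a small step is expected. For compound 4 the step is expected to be a 1.1-fold lower number from compound 3 to compound 4 (0.03 log units; within the scatter). Compound 4 is estimated at 35000 nM, with a range from 20000 nM to 60000 nM.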

Compound 4, half-maximal inhibitory concentration: 37800 nM
Estimate against measurement, compound 4: 1.1-fold (0.03 log units) below; the range from low to high includes it.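

In this assay, methoxy in place of fluoro on the fluorinated core gives no change at the digits printed from compound 3 to compound 4 (within the scatter), which agrees with the earlier step: the same change on two cores in this assay, a 1.1-fold lower number (0.04 log units; within the scatter) from compound 1 to compound 2 and no change at the digits printed (within the scatter) from compound 3 to compound 4, 1.1-fold (0.04 log units) apart, within the scatter of two such steps

Fluoro in place of hydrogen gives a 1.0-fold higher number from compound 2 to compound 4 (0.02 log units; within the scatter), and this also agrees with its earlier step: the same change on two cores in this assay, a 1.1-fold lower number (0.02 log units; within the scatter) from compound 1 to compound 3 and a 1.0-fold higher number (0.02 log units; within the scatter) from compound 2 to compound 4, 1.1-fold (0.04 log units) apart, within the scatter of two such steps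

Among these compounds, both changes therefore carry from one core to the other with no step beyond the scatter, but this shows only that small steps stay small on these two cores, not how a change that truly moves the number would carry.

Still open, as far as these compounds go, is whether any group at this place moves the number in this assay. An amine or a carboxylic acid on the same aromatic carbon, in place of fluoro or methoxy, would test that.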